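The compounds below may be only part of what the source reports. "The series", "measured", "known", "first", "only" and "open" are said of these compounds alone.

Three compounds share one core and differ only in the group on the aromatic nitrogen. Compound 1 `CCOC(=O)c1c(-c2cc3ccccc3oc2=O)nn(-c2cccc(C)c2)c1C(=O)OCC` gives 47000 nM in a functional assay on DU-145 cells (Homo sapiens) for cytotoxicity, read by MTT assay, with a stated time of 48 h; on this read-out higher numbers stand for weaker inhibition and lower numbers for stronger inhibition. Compound 2 `CCOC(=O)c1c(-c2cc3ccccc3oc2=O)nn(-c2ccc(C)c(C)c2)c1C(=O)OCC` gives 40000 nM, and compound 3 `CCOC(=O)c1c(-c2cc3ccccc3oc2=O)nn(-c2cccc(Cl)c2)c1C(=O)OCC` gives 35000 nM. The steps between them, a 1.2-fold lower number from compound 1 to compound 2 (0.07 log units; within the scatter), a 1.3-fold lower number from compound 1 to compound 3 (0.13 log units; within the scatter) and a 1.1-fold lower number from compound 2 to compound 3 (0.06 log units; within the scatter), are all within the scatter, so the three numbers are effectively one. Compound 3 carries the lowest of the three numbers, but its distance to either neighbour stays within the scatter.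

Compound 4 `CCOC(=O)c1c(-c2cc3ccc(OCC=C(C)C)cc3oc2=O)nn(-c2cccc(Cl)c2)c1C(=O)OCC` moves the change to the other side of the core: (3-methylbut-2-en-1-yl)oxy in place of hydrogen on an aromatic carbon. Going by the values given here, none of the measured steps touches this ring, so they give no direct guide to this change; they only show that the core has so far tolerated changes without moving the number beyond the scatter.

For compound 4 the expected result is a 1.2-fold lower number from compound 3 to compound 4 (0.07 log units; within the scatter), that is, no step beyond the scatter. The estimate for compound 4 is 30000 nM, within a range from 10000 nM to 90000 nM.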

Compound 4, half-maximal inhibitory concentration: 139000 nM
The estimate for compound 4 lay 4.6-fold (0.67 log units) below the measured number; the measured number lies above the stated range.
By their numbers in this assay, from the lowest: compounds 3, 2 and 1 (each within the scatter of the next); then compound 4.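

Adding a (3-methylbut-2-en-1-yl)oxy group to this aromatic carbon of the fused two-ring system in this assay gives a 4.0-fold higher number from compound 3 to compound 4 (0.60 log units; beyond the scatter), a modest move towards weaker inhibition. Going by these compounds alone, this is the first step that lies beyond the scatter: the swaps on the aromatic nitrogen among compounds 1, 2 and 3 all stayed within it. The number at this carbon can therefore respond to a substituent, even though the nitrogen swaps left it effectively unchanged, but no measurement shown here explains the rise.

As far as these compounds go, with only one substituent at this position, it remains open whether a small methoxy group, a hydroxyl group or a longer chain such as geranyloxy would give a similar step. From the compounds shown here alone, it also remains open whether the same group would have the same effect alongside the 3-methylphenyl or 3,4-dimethylphenyl group of compound 1 or compound 2.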